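Imidazole variation on the piperazine methylene

This account rests on a few compounds, and the source may have more. Where it says the series, first, only, none or still open, it means among the compounds named here.

In an assay on isolated protein for displacement of a labelled ligand from Gonadotropin-releasing hormone receptor (Homo sapiens) (on this read-out lower numbers stand for stronger inhibition and higher numbers for weaker inhibition), compound 2 `CCc1nc(CN2CCN(c3cccc4[nH]c(-c5ccc(C(C)(C)C)cc5)nc34)CC2)cn1C` gives 18 nM and compound 1 `Cc1nc(CN2CCN(c3cccc4[nH]c(-c5ccc(C(C)(C)C)cc5)nc34)CC2)c(C)s1` gives 21 nM; of the two numbers shown, that of compound 2 is the smaller, though a 1.2-fold lower number from compound 1 to compound 2 (0.07 log units; within the scatter) stays within the scatter. Compound 3 `CCCn1c(CC)nc(C)c1CN1CCN(c2cccc3[nH]c(-c4ccc(C(C)(C)C)cc4)nc23)CC1` carries 2-ethyl-4-methyl-1-propyl-1H-imidazol-5-yl in place of 2-ethyl-1-methyl-1H-imidazol-4-yl on a saturated chain carbon bound to an amine nitrogen in a ring. Among the compounds with values here, the only measured step that bears on this place, an exchange of the five-membered aromatic ring there, was a 1.2-fold lower number from compound 1 to compound 2 (0.07 log units; within the scatter), so no step beyond the scatter is expected in this assay. Compound 3 is expected to give 20 nM, within 8 nM to 50 nM. The expected step is a 1.1-fold higher number from compound 2 to compound 3 (0.05 log units; within the scatter).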

Compound 3, half-maximal inhibitory concentration: 57 nM
Compound 3: the middle estimate sits 2.9-fold (0.45 log units) below what was measured, outside the stated range (above it).
By their numbers in this assay, from the lowest: compounds 2 and 1 (each within the scatter of the next); then compound 3.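

In this assay this place is no longer silent: 2-ethyl-4-methyl-1-propyl-1H-imidazol-5-yl gives a 3.2-fold higher number from compound 2 to compound 3 (0.50 log units; beyond the scatter), and measured against 2,5-dimethyl-1,3-thiazol-4-yl it gives a 2.7-fold higher number from compound 1 to compound 3 (0.43 log units; beyond the scatter). Not every five-membered aromatic ring on this saturated chain carbon is therefore equivalent, although compound 1 and compound 2 remained within the scatter of each other. No available evidence accounts for the loss.

As far as these compounds go, compound 3 alters the ring's substituents and its point of attachment together, so the source of the step remains open. Also open, from the compounds shown here alone, is whether a 1-butyl chain or an amine on the 1-propyl chain would be tolerated.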